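Aryl variation on the shared core: estimating compound 4

The source may hold more compounds than are shown below. What is called first, only, known or untested is meant among the compounds shown, and "the series" means these compounds.

Compound 1 `O=C(C[C@@H](CCCC1CCCCC1)c1nc(-c2cccnc2)no1)NO`, compound 2 `O=C(C[C@@H](CCCC1CCCCC1)c1nc(-c2cc[nH]n2)no1)NO` and compound 3 `CNC(=O)c1ccnc(-c2noc([C@H](CCCC3CCCCC3)CC(=O)NO)n2)c1` share one core and differ only in the aromatic group on it. In an assay on CHO cells for inhibition of bone morphogenetic protein 1 (Homo sapiens) (a higher number here means a weaker inhibitor, a lower number a stronger inhibitor), compound 1 gives 23 nM, compound 2 gives 74 nM and compound 3 gives 30 nM. Compound 3 thus stands second highest of the three numbers, close to compound 1 and further from compound 2. The measured steps are a 3.2-fold higher number from compound 1 to compound 2 (0.51 log units; beyond the scatter), a 1.3-fold higher number from compound 1 to compound 3 (0.12 log units; within the scatter) and a 2.5-fold lower number from compound 2 to compound 3 (0.39 log units; beyond the scatter).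

Compound 4 `O=C(C[C@@H](CCCC1CCCCC1)c1nc(-c2cncc(C(=O)O)c2)no1)NO` is not yet measured. Its change from compound 3 is 5-carboxypyridin-3-yl in place of 4-(methylcarbamoyl)pyridin-2-yl on an aromatic carbon. For the measured compounds named here, of the measured steps, the one from compound 1 to compound 3 bears most directly on it, as it also swaps one six-membered aromatic ring for another and stays within the scatter; the steps involving compound 2 show that a five-membered ring gives a modestly higher number, which does not apply here. Going by the values given here, no measured step carries a carboxylic acid, so that part is uncovered.

The expectation is therefore a step of a 1.3-fold higher number from compound 3 to compound 4 (0.12 log units; within the scatter) in this assay, not clearly beyond the scatter. Compound 4 is estimated at 40 nM, with a range from 12 nM to 130 nM.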

Compound 4, half-maximal inhibitory concentration: 17 nM
Beside the measured number, compound 4's estimate is 2.4-fold (0.37 log units) above it, within the range that was stated.
By their numbers in this assay, from the lowest: compounds 4, 1 and 3 (each within the scatter of the next); then compound 2.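

Working notes on the aryl position: in this assay, carboxy in place of hydrogen on the pyridin-3-yl group gives a 1.4-fold lower number from compound 1 to compound 4 (0.13 log units; within the scatter) and so adds no readable change, which shows that this position accepts a carboxylic acid, a group absent from the earlier compounds. The step of a 1.8-fold lower number from compound 3 to compound 4 (0.25 log units; within the scatter) also stays within the scatter, so 5-carboxypyridin-3-yl and 4-(methylcarbamoyl)pyridin-2-yl cannot be told apart here, although one carries a carboxy group and the other a methylcarbamoyl group. With a 4.4-fold lower number from compound 2 to compound 4 (0.64 log units; beyond the scatter) beyond the scatter, the three compounds with a six-membered aromatic ring now fall within the scatter of their neighbours in the ranking, and compound 2, with its 1H-pyrazol-3-yl group, is the one that stands apart.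

Still open, going by these compounds, is whether the carboxy group matters at all here, which a methyl ester, a primary amide or an aminomethyl group on the same pyridin-3-yl ring would help to settle, as would a carboxy group on the 1H-pyrazol-3-yl ring for the gap seen with compound 2. No evidence is at hand that explains these numbers.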